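A few compounds are considered here, and "the series" means these few. Any claim that something is new, unique, unknown or untested is made for them only; others in the source may bear on it.

Compound 1 `Cn1c(-c2cccc(Cl)c2)cnc1NC(=O)c1ccc(F)cc1` was examined in a toxicity assay on THP-1 cells (Homo sapiens) for inhibition; a higher number here means that more compound is tolerated, a lower number that less compound is tolerated. In this assay compound 1 gives > 50000 nM, which is a limit of the assay and not a number. Compound 2 `COc1ccc(-c2cnc(NC(=O)C3CCCCC3)n2C)cc1` was examined alongside it. In this assay compound 2 gives > 100000 nM, again a limit rather than a number. Among the compounds with values here, both values shown are therefore limits, one sitting at the limit of > 100000 nM in this assay, at which 1 of the 2 values shown sits, and one at the limit of > 50000 nM in this assay, at which 1 of the 2 values shown sits, so the two values show only that neither compound reached measurable toxicity, and compound 1 cannot be placed above or below compound 2.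

Compound 3 `Cn1c(-c2cccc(F)c2)cnc1NC(=O)c1ccc(F)cc1` differs from compound 1 by one change, fluoro in place of chloro on an aromatic carbon: the chloro leaves and a fluoro enters on the aromatic carbon of the six-membered carbon ring. Within the data shown here, with no measured step available for comparison, the expectation is no step beyond the scatter in this assay. Compound 3 is estimated to give 80000 nM, within 40000 nM to 200000 nM. The step that the limit leaves unreadable from compound 1 to compound 3 that this estimate implies is expected to fall within the usual scatter.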

Compound 3, half-maximal cytotoxic concentration: 58000 nM
The estimate for compound 3 lay 1.4-fold (0.14 log units) above the measured number, within the range that was stated.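

In this assay, within the data shown here, compound 1 gives > 50000 nM, which is a limit and not a number, so no step to compound 3 can be read from it. The compounds shown leave open whether fluoro in place of chloro on the aromatic carbon changes how much compound is tolerated at all.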